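Propyl Ester in Place of Methyl on a Thiophene Dihydropyrimidinone

The compounds below may be only part of what the source reports. "The series", "measured", "known", "first", "only" and "open" are said of these compounds alone.

Compound 2 `COC(=O)C1=C(C)N(C)C(=O)NC1c1cccs1` is the higher of two measured compounds in an assay on membranes from HEK293 cells for displacement of a labelled ligand from adenosine receptor A2b (Homo sapiens), read by scintillation counting, with a stated time of 30 min, tested at 1 uM; a higher number here means more inhibition at the concentration tested (going by the name of the read-out), a lower number less inhibition; in this assay compound 2 gives 17%, while compound 1 `CCCOC(=O)C1=C(C)N(C)C(=O)NC1c1ccoc1` gives 2%, a gap beyond the scatter. Compound 3 `CCCOC(=O)C1=C(C)N(C)C(=O)NC1c1cccs1` is compound 2 carrying (ethyl in place of hydrogen on a saturated chain carbon bound to an oxygen next to a carbonyl group). For the measured compounds named here, no single-change step between measured compounds exists to guide the size of this step, so only a small step from compound 2, or none beyond the scatter, is expected: a number 4 percentage points lower from compound 2 to compound 3 (within the scatter). Compound 3 is estimated to give 13%, within 0% to 35%.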

Compound 3, a percentage reported as inhibition, at one concentration (the size of the read-out at that concentration, not a potency): 1%
Estimate against measurement, compound 3: 12 percentage points above; measured number inside the range.
By their numbers in this assay, from the lowest: compounds 3 and 1 (each within the scatter of the next); then compound 2.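

Propoxycarbonyl in place of methoxycarbonyl gives a number 16 percentage points lower from compound 2 to compound 3 (beyond the scatter) in this assay and so shows that inhibition responds to a change at this place. With propoxycarbonyl held, thiophen-2-yl in place of furan-3-yl gives a number 1 percentage points lower from compound 1 to compound 3 (within the scatter) and leaves the two ring groups apart by no more than the scatter at these low values. Nothing measured here explains the loss on going to the propyl ester.

Open, as far as these compounds go, is whether the step from methyl follows chain length, as an ethyl or butyl ester or a carboxylic acid at this place could show. Also open, from the compounds shown here alone, is how furan-3-yl compares with thiophen-2-yl when methoxycarbonyl is held.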